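A few compounds are considered here, and "the series" means these few. Any claim that something is new, unique, unknown or untested is made for them only; others in the source may bear on it.

Measured in a functional assay on SW480 cells (Homo sapiens) for antiproliferative activity, read by MTT assay, with a stated time of 48 h; on this read-out higher numbers stand for weaker inhibition and lower numbers for stronger inhibition:
- Compound 1 `CCCCCCCC(CCO)n1cnc2c(Cl)ncnc21`: 3630 nM
- Compound 2 `CCCCCCC[C@@H](CCO)n1cnc2c(Cl)ncnc21`: 3820 nM
- Compound 3 `CCCCCCC[C@H](CCO)n1cnc2c(Cl)ncnc21`: 2930 nM

On these numbers, compound 3 cannot be told apart from the other two. The measured steps are a 1.1-fold higher number from compound 1 to compound 2 (0.02 log units; within the scatter), a 1.2-fold lower number from compound 1 to compound 3 (0.09 log units; within the scatter) and a 1.3-fold lower number from compound 2 to compound 3 (0.12 log units; within the scatter), and each lies within the scatter. All three concern configuration only, and none alters the chain. Compound 4 `CCCCCCCC[C@H](CCO)n1cnc2c(Cl)ncnc21` differs from compound 3 by methyl in place of hydrogen on a saturated chain carbon, eight bonds along the chain from an aromatic nitrogen. The measured steps therefore bear on this change only indirectly, and no step beyond the scatter is expected in this assay. The expected change is a 1.0-fold higher number from compound 3 to compound 4 (0.01 log units; within the scatter). For compound 4 the estimated value is 3000 nM, with an expected range of 1500 nM to 6000 nM.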

Compound 4, half-maximal inhibitory concentration: 320 nM
For compound 4 the middle estimate is 9.4-fold (0.97 log units) above the measured one; measured number below the stated range.
By their numbers in this assay, from the lowest: compound 4; then compounds 3, 1 and 2 (each within the scatter of the next).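

In this assay, methyl in place of hydrogen on a saturated chain carbon, eight bonds along the chain from an aromatic nitrogen, gives a 9.2-fold lower number from compound 3 to compound 4 (0.96 log units; beyond the scatter). So this position responds to a single added carbon, whereas the configuration changes among compound 1, compound 2 and compound 3 stayed within the scatter. Nothing in the information available accounts for this step.

On these data alone, whether a longer chain at this position would lower the number further remains open, as does what an amine or a carboxylic acid there would give.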